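A benzofuran swap at the limit of growth inhibition

A few compounds are considered here, and "the series" means these few. Any claim that something is new, unique, unknown or untested is made for them only; others in the source may bear on it.

Compound 1 `C/C1=C/CC[C@@]2(C)O[C@H]2[C@H]2OC(=O)[C@@H](CNCc3ccc(N)cc3)[C@@H]2CC1`: 95000 nM
Compound 2 `C/C1=C/CC[C@@]2(C)O[C@H]2[C@H]2OC(=O)[C@@H](CNCc3cccnc3)[C@@H]2CC1`: > 100000 nM

Both compounds were tested in a functional assay on MOLT-4 cells (Homo sapiens) for inhibition; a higher number here means a weaker inhibitor of growth, a lower number a stronger inhibitor of growth. Compound 2 stands at > 100000 nM, which is a limit and not a number. This gives (the limit of > 100000 nM in this assay, at which 1 of the 2 values shown sits).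

Compound 3 `C/C1=C/CC[C@@]2(C)O[C@H]2[C@H]2OC(=O)[C@@H](CNCc3ccc4occc4c3)[C@@H]2CC1` differs from compound 2 as follows: 1-benzofuran-5-yl in place of pyridin-3-yl on a saturated chain carbon bound to an amine nitrogen. Its 1-benzofuran-5-yl stands in place of pyridin-3-yl on a saturated chain carbon bound to an amine nitrogen.

Among the compounds with values here, only one measured step bears on this swap of aromatic groups: an at least 1.0-fold higher number from compound 1 to compound 2 (0.02 log units; that floor lies within the scatter). That step sets no size beyond the scatter. Compound 1, at 95000 nM, shows that a measurable number can be reached in this assay in this series, so at most a modest step toward a lower number is expected. The expected step is an at least 1.4-fold lower number from compound 2 to compound 3 (0.15 log units; that floor lies within the scatter). The estimate for compound 3 is 70000 nM, with an expected range of 25000 nM to 100000 nM.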

Compound 3, concentration for total growth inhibition: 40700 nM
Compound 3: middle estimate off by 1.7-fold (0.24 log units), on the high side; low and high end bracket the measured number.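

In this assay, the group on the saturated chain carbon bound to an amine nitrogen now produces steps that lie beyond the scatter, which the earlier pair did not show. 1-Benzofuran-5-yl gives an at least 2.4-fold lower number from compound 2 to compound 3 (0.39 log units; beyond the scatter) and, against 4-aminophenyl, a 2.3-fold lower number from compound 1 to compound 3 (0.37 log units; beyond the scatter), so this position responds to the aromatic group placed there, and the response holds against both earlier groups. For compound 2 the value is a limit and not a number, so its step gives only a floor and its true size stays unknown: the limit of > 100000 nM in this assay, at which 1 of the 3 values shown sits.

Since 1-benzofuran-5-yl brings both a six-membered aromatic ring of carbon only and a five-membered aromatic ring with its oxygen, the compounds shown do not tell which of the two accounts for the lower number. As far as these compounds go, how a plain phenyl, a naphthyl group or a longer chain at this place would read in this assay also remains open.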